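The source may hold more compounds than are shown below. What is called first, only, known or untested is meant among the compounds shown, and "the series" means these compounds.

In a functional assay on HCT-116 cells (Homo sapiens) for cytotoxicity, read by resazurin assay, with a stated time of 48 h (a lower number here means that less compound is needed, a higher number that more compound is needed for the effect), three compounds have been measured so far. Compound 1 (`COc1ccc(S(=O)(=O)Nc2ccc3oc(-c4ccc(NS(=O)(=O)c5cc(Br)ccc5OC)cc4)nc3c2)cc1`) gives 12000 nM, compound 2 (`COc1c(Br)cccc1C(=O)Nc1ccc(Sc2nc3ccccc3s2)cc1`) gives 31000 nM and compound 3 (`COc1c(Br)cccc1C(=O)Nc1ccc(Sc2nc3ccccc3s2)c(Cl)c1`) gives 8500 nM. Compound 2 therefore has the highest number of the three, meaning that the most compound is needed for the effect, and its gaps to both others lie beyond the scatter.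

Compound 4 (`O=C(Nc1ccc(Sc2nc3ccccc3s2)cc1)c1cc(Br)cc(Br)c1O`) differs from compound 2 in one place: a group of 9 heavy atoms (6 carbon, 1 oxygen, 2 bromine; one six-membered aromatic ring of carbon only) in place of a group of 9 heavy atoms (7 carbon, 1 oxygen, 1 bromine; one six-membered aromatic ring of carbon only), on a carbonyl carbon. The group that enters is 3,5-dibromo-2-hydroxyphenyl. For the measured compounds named here, no measured step makes this exchange, so the only guide is an indirect one: a 3.6-fold lower number from compound 2 to compound 3 (0.56 log units; beyond the scatter), where a chloro took the place of a hydrogen on an aromatic carbon. Going by the size of that single modest step, a similar move towards a lower number is expected in this assay, with considerable uncertainty. The estimated change is a 3.1-fold lower number from compound 2 to compound 4 (0.49 log units; beyond the scatter). For compound 4 the estimated value is 10000 nM, with an expected range from 2500 nM to 35000 nM.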

Compound 4, half-maximal effective concentration: 19000 nM
The estimate for compound 4 lay 1.9-fold (0.28 log units) below the measured number; the measured number falls inside the stated range.
By their numbers in this assay, from the lowest: compounds 3, 1, 4 and 2 (each within the scatter of the next, the first and the last beyond it).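

In this assay, placing 3,5-dibromo-2-hydroxyphenyl on the carbonyl carbon gives a 1.6-fold lower number from compound 2 to compound 4 (0.21 log units; within the scatter), so the two groups cannot be told apart in this assay, even though the entering group brings a second bromine and a hydrogen-bond donor. For the compounds shown here, this is the first view of that position, since the earlier step, a 3.6-fold lower number from compound 2 to compound 3 (0.56 log units; beyond the scatter), concerned a chloro on an aromatic carbon elsewhere in the molecule and kept this group unchanged. No supporting data bear on why this exchange has so little effect.

The exchange alters several features at once, so the contribution of the second bromine cannot be separated from that of the hydroxy group. Going by these compounds, it also remains open whether a plain phenyl, or a ring carrying an amine or a carboxylic acid, on this carbonyl carbon would shift the number beyond the scatter.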